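The source may report more compounds than this note shows. Statements on the series, on what has been measured and on what is new or still open speak of the compounds shown alone.

Compound 1 `COc1cc2c(Nc3ccc4sc(C(=O)Nc5c(C)cccc5Cl)cc4c3)ncnc2cc1OCCCN1CCCCC1C` gives 2150 nM in a functional assay on K562 cells (Homo sapiens) for cytotoxicity, read by MTT assay and WST assay, with a stated time of 72 h; a higher number here means a weaker inhibitor, a lower number a stronger inhibitor.
Compound 2 `CCN(CC)CCCOc1cc2ncnc(Nc3ccc4sc(C(=O)Nc5c(C)cccc5Cl)cc4c3)c2cc1OC` gives 3550 nM in this assay.
Compound 3 `Cc1nc(Nc2ccc3sc(C(=O)Nc4c(C)cccc4Cl)cc3c2)cc(N2CCN(C)CC2)n1` gives 17000 nM in this assay.

Compound 2 stands second highest of these three numbers, nearest to compound 1 and furthest from compound 3. Compound 4 `COc1cc2c(Nc3ccc4sc(C(=O)Nc5c(C)cccc5Cl)cc4c3)ncnc2cc1OCCCN1CCN(C)CC1` differs from compound 2 by 4-methylpiperazin-1-yl in place of diethylamino on a saturated chain carbon, three bonds along the chain from an oxygen on an aromatic ring. Among the compounds with values here, the only measured step at the same place is a 1.7-fold higher number from compound 1 to compound 2 (0.22 log units; within the scatter), which lies within the scatter. Compound 3 carries the entering group on a different core, so its number shows only that it is the highest of the three and offers no single-change comparison. No step beyond the scatter is therefore expected in this assay for compound 4. Compound 4 is estimated at 3000 nM, between 1200 nM and 8000 nM, an expected step of a 1.2-fold lower number from compound 2 to compound 4 (0.07 log units; within the scatter).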

Compound 4, half-maximal inhibitory concentration: 9880 nM
Beside the measured number, compound 4's estimate is 3.3-fold (0.52 log units) below it, outside the stated range (above it).
By their numbers in this assay, from the lowest: compounds 1 and 2 (each within the scatter of the next); then compounds 4 and 3 (each within the scatter of the next).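

In this assay the amine on this chain now makes a difference: the move shows a 2.8-fold higher number from compound 2 to compound 4 (0.44 log units; beyond the scatter) and the comparison with the other ring shows a 4.6-fold higher number from compound 1 to compound 4 (0.66 log units; beyond the scatter), whereas the earlier step at this place stayed within the scatter. A ring alone does not set this apart, since compound 1 also carries a six-membered ring, but without the second ring nitrogen of 4-methylpiperazin-1-yl. No measured evidence accounts for the step.

From the compounds shown here alone, whether the second ring nitrogen or its methyl matters remains open. Morpholin-4-yl or unsubstituted piperazin-1-yl on the same propyl chain could separate these possibilities.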